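Halogenated aryl hydrazones: a single swap on compound 2

The source may report more compounds than this note shows. Statements on the series, on what has been measured and on what is new or still open speak of the compounds shown alone.

Measured in a functional assay on PC-3 cells (Homo sapiens) for antiproliferative activity, read by MTT assay (on this read-out lower numbers stand for stronger inhibition and higher numbers for weaker inhibition), so far:
- compound 1, `Cn1c(=O)c(=O)n(C2CCCC2)c2nc(N/N=C/c3cc(C(F)(F)F)c(O)c(C(F)(F)F)c3)ncc21`, gives 17700 nM
- compound 2, `Cn1c(=O)c(=O)n(C2CCCC2)c2nc(N/N=C/c3cccc(Cl)c3Cl)ncc21`, gives 17200 nM
- compound 3, `Cn1c(=O)c(=O)n(C2CCCC2)c2nc(N/N=C/c3cc(C(F)(F)F)cc(C(F)(F)F)c3)ncc21`, gives 8200 nM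

Going by the values given here, compound 2 sits second highest of the three numbers, within the scatter of compound 1 and separated from compound 3 by a 2.2-fold lower number from compound 1 to compound 3 (0.33 log units; beyond the scatter) being the only step with a comparable size. Compound 4, `Cn1c(=O)c(=O)n(C2CCCC2)c2nc(N/N=C/c3ccc(F)cc3Br)ncc21`, differs from compound 2 by 2-bromo-4-fluorophenyl in place of 2,3-dichlorophenyl on a carbon with a double bond to nitrogen. Among the compounds with values here, no measured step touches this swap; the one step on record, hydrogen in place of hydroxy, is modest. A halogen-for-halogen aryl change is expected to stay within the scatter, so a 1.1-fold lower number from compound 2 to compound 4 (0.06 log units; within the scatter) is the expected step. Compound 4 is estimated at 15000 nM, in the range 6000 nM to 40000 nM.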

Compound 4, half-maximal inhibitory concentration: 9250 nM
For compound 4 the middle estimate is 1.6-fold (0.21 log units) above the measured one, within the range that was stated.
By their numbers in this assay, from the lowest: compounds 3, 4, 2 and 1 (each within the scatter of the next, the first and the last beyond it).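

In this assay, a 1.9-fold lower number from compound 2 to compound 4 (0.27 log units; within the scatter) stays within the scatter, so replacing 2,3-dichlorophenyl with 2-bromo-4-fluorophenyl on the carbon with a double bond to nitrogen gives no readable change. Unlike the earlier hydroxy-to-hydrogen step, this swap exchanges the entire aryl group, with heavy-atom count and donor and acceptor counts unchanged. No available evidence explains this outcome.

As far as these compounds go, it remains open whether an aryl group bearing an amine or a carboxylic acid would depart from this halogen pair. The separate contributions of the bromine and fluorine also remain unresolved.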